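Spiro series: furan-2-yl for 4-chlorophenyl, second instance

This account rests on a few compounds, and the source may have more. Where it says the series, first, only, none or still open, it means among the compounds named here.

Of the compounds shown here, three have been measured in a functional assay on the whole organism (strain Wister albino) for inhibition, with Rattus norvegicus as the target, read by paw edema, with stated times of 1 h and 2 h, at a dose of 50 mg/kg by the intraperitoneal route; a lower number here means less inhibition, a higher number more inhibition at the dose given (going by the name of the read-out). Compound 1 `CN1C(=O)[C@@]2(c3ccccc31)N(C)C[C@@H](c1ccco1)[C@@]21Cc2ccccc2C1=O` gives 33.1%. Compound 2 `CN1C[C@@H](c2ccc(Cl)cc2)[C@@]2(Cc3ccccc3C2=O)[C@@]12C(=O)Nc1ccccc12` gives 28.4%. Compound 3 `CN1C(=O)[C@@]2(c3ccccc31)N(C)C[C@@H](c1ccc(Cl)cc1)[C@@]21Cc2ccccc2C1=O` gives 36.3%. All three numbers lie within the scatter of one another, so no order among them can be read from these data.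

One structural change recurs in the set. From compound 3 to compound 1 the change is furan-2-yl in place of 4-chlorophenyl on a saturated ring carbon, and the step was a number 3.2 percentage points lower from compound 3 to compound 1 (within the scatter). The core of compound 2 differs from the core of compound 3 in that (hydrogen in place of methyl on an amide-type nitrogen in a ring), with a step of a number 7.9 percentage points higher from compound 2 to compound 3 (within the scatter).

Compound 4 `CN1C[C@@H](c2ccco2)[C@@]2(Cc3ccccc3C2=O)[C@@]12C(=O)Nc1ccccc12` has not yet been measured in this assay. It arises from compound 2 by furan-2-yl in place of 4-chlorophenyl on a saturated ring carbon, the same change as from compound 3 to compound 1, at a place described in identical words. Going by the values given here, the expected step is a number 3.2 percentage points lower from compound 2 to compound 4 (within the scatter), which rests on the one measured pair, where the step was a number 3.2 percentage points lower from compound 3 to compound 1 (within the scatter). Compound 4 is therefore estimated at 25.2%. The precedent is a single pair, so the bounds are kept wide.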

Compound 4, a percentage reported as inhibition, in the whole organism at one dose (the size of the read-out at that dose, not a potency): 53.6%
Beside the measured number, compound 4's estimate is 28.4 percentage points below it; measured number outside the range, above it.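

In this assay, furan-2-yl in place of 4-chlorophenyl gives a number 25.2 percentage points higher from compound 2 to compound 4 (beyond the scatter), and this step does not carry over between the two cores: the same change on two cores in this assay, a number 3.2 percentage points lower (within the scatter) from compound 3 to compound 1 and a number 25.2 percentage points higher (beyond the scatter) from compound 2 to compound 4, 28.4 percentage points apart, beyond the scatter of two such steps

Hydrogen in place of methyl on the amide-type nitrogen likewise depends on the group on the saturated ring carbon, with a number 20.5 percentage points higher from compound 1 to compound 4 (beyond the scatter), so the two changes do not add up across this set: the same change on two cores in this assay, a number 7.9 percentage points higher (within the scatter) from compound 2 to compound 3 and a number 20.5 percentage points lower (beyond the scatter) from compound 4 to compound 1, 28.4 percentage points apart, beyond the scatter of two such steps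

Going by these compounds alone, both comparisons rest on the same four compounds and turn on the single reading of compound 4, so they amount to one observation, which gives neither a cause nor a rule for other cores.

From the compounds shown here alone, whether the higher reading of compound 4 is specific to furan-2-yl remains open, as a thiophen-2-yl or pyridinyl group at the same place would be needed to test it. Also open, going by these compounds, is how an ethyl group on the amide-type nitrogen would behave alongside furan-2-yl.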